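This account rests on a few compounds, and the source may have more. Where it says the series, first, only, none or still open, it means among the compounds named here.

Of the compounds shown here, three built on one shared core have been measured in an assay on isolated protein for inhibition of leucine--tRNA ligase, cytoplasmic (Homo sapiens); a lower number here means a stronger inhibitor, a higher number a weaker inhibitor. Compound 1 `CC(C)C[C@H](N)C(=O)NS(=O)(=O)c1cccc(-c2ccccc2)c1` gives 3400 nM. Compound 2 `CC(C)C[C@H](N)C(=O)NS(=O)(=O)c1ccccc1` gives 1100 nM. Compound 3 `CC(C)C[C@H](N)C(=O)NS(=O)(=O)c1ccc2ccccc2c1` gives 220 nM. Among these three numbers compound 2 stands second highest, with compound 1 its nearest neighbour and compound 3 furthest from it. Among the measured compounds shown here, only one of these pairs differs in a single place: the change from compound 1 to compound 2, hydrogen in place of phenyl on an aromatic carbon, brought a 3.1-fold lower number from compound 1 to compound 2 (0.49 log units; beyond the scatter). Compound 3 is not a single-place change from compound 2, so its value serves only as a second point of reference.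

Compound 4 `CC(C)C[C@H](N)C(=O)NS(=O)(=O)c1cccc(-c2ccnc(N)n2)c1` has not yet been measured. It differs from compound 2 by 2-aminopyrimidin-4-yl in place of hydrogen on an aromatic carbon. For the measured compounds named here, the one measured step that bears on this, from compound 1 to compound 2, runs the other way: removing a ring from that carbon lowered the number, so placing a ring there again would be expected to raise it by a similar modest amount. Going by the values given here, the entering group is not phenyl, and no measured pair shows what 2-aminopyrimidin-4-yl does at this position, so the expectation is loose. Compound 4 is therefore estimated at 3000 nM, between 700 nM and 12000 nM. This corresponds to an expected step of a 2.7-fold higher number from compound 2 to compound 4 (0.44 log units; beyond the scatter).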

Compound 4, half-maximal inhibitory concentration: 3900 nM
Compound 4: middle estimate off by 1.3-fold (0.11 log units), on the low side; the measured number falls inside the stated range.
By their numbers in this assay, from the lowest: compound 3; then compound 2; then compounds 1 and 4 (each within the scatter of the next).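

In this assay, putting 2-aminopyrimidin-4-yl in place of hydrogen on this aromatic carbon brought a 3.5-fold higher number from compound 2 to compound 4 (0.55 log units; beyond the scatter), so the earlier rise seen with phenyl is not unique to phenyl: both rings tested here give a weaker inhibitor than hydrogen does. Exchanging phenyl for 2-aminopyrimidin-4-yl gave a 1.1-fold higher number from compound 1 to compound 4 (0.06 log units; within the scatter), which means the two rings cannot be told apart at this position in this assay, even though the entering ring brings nitrogen atoms and a hydrogen-bond donor that phenyl does not have. Nothing available explains why these two rings give a higher number than hydrogen or why they match each other.

The compounds shown compare only hydrogen and two six-membered aromatic rings on this carbon, so it remains open whether a much smaller group, such as methyl, an amine or a carboxylic acid, would behave like hydrogen or like the rings. From the compounds shown here alone, it also remains open whether a ring held away from this carbon by a short carbon chain would give a number closer to that of compound 2 or to those of compound 1 and compound 4.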